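The source may report more compounds than this note shows. Statements on the series, on what has been measured and on what is new or still open speak of the compounds shown alone.

Compound 2 `COc1cc(-c2nnc(SCC(=O)c3ccc(F)c(F)c3)n2N)cc(OC)c1OC` stands at the edge of what a functional assay on PC-3 cells (Homo sapiens) for antiproliferative activity, read by MTT assay, with a stated time of 48 h (on this read-out lower numbers stand for stronger inhibition and higher numbers for weaker inhibition), can report: in this assay compound 2 gives > 100000 nM, which is a limit of the assay and not a number, the limit described as the limit of > 100000 nM in this assay, at which 1 of the 2 values shown sits. For the measured compounds named here, its one measured neighbour is compound 1 `COc1cc(-c2nnc(SCC(=O)c3ccc(C)cc3)n2N)cc(OC)c1OC`, which carries 4-methylphenyl on the carbonyl carbon; in this assay compound 1 gives 31300 nM. Going by the values given here, the only measured step, an at least 3.1-fold higher number from compound 1 to compound 2 (0.50 log units; beyond the scatter), is the exchange of that 4-methylphenyl for 3,4-difluorophenyl, and it moved the number at least modestly towards weaker inhibition. Compound 3 `COc1cc(-c2nnc(SCC(=O)Nc3ccccc3C)n2N)cc(OC)c1OC` is reached from compound 2 by (2-methylphenyl)amino in place of 3,4-difluorophenyl on a carbonyl carbon. Among the compounds with values here, no measured step exchanges an aryl group for an arylamino group on this carbonyl carbon, so the step from compound 1 to compound 2 shows only that the group on the carbonyl carbon changes the read-out in this assay. With compound 2 at a limit, the step to compound 3 cannot be sized as a number. The firm anchor is compound 1 at 31300 nM. Compound 3 is therefore expected to give roughly 50000 nM, between 15000 nM and 200000 nM, an expected step of an at least 2.0-fold lower number from compound 2 to compound 3 (0.30 log units; that floor lies within the scatter).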

Compound 3, half-maximal inhibitory concentration: > 100000 nM
Compound 3 was reported as a limit; the forecaster's own chance of this, stated with the estimate: 40%; middle value at least 2.0-fold (0.30 log units) away from the limit.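

In this assay compound 3 gives > 100000 nM, which is a limit of the assay and not a number. The (2-methylphenyl)amino group thus joins 3,4-difluorophenyl in taking the read-out on this carbonyl carbon out of measurable range, and its exchange for 4-methylphenyl brings an at least 3.1-fold higher number from compound 1 to compound 3 (0.50 log units; beyond the scatter), so that a replacement of a different kind, with an amino hydrogen added, also moves towards weaker inhibition and 4-methylphenyl remains the only group shown here that gives a number. The step between compound 2 and compound 3 cannot be read, since both sit at the same limit: the limit of > 100000 nM in this assay, at which 2 of the 3 values shown sit.

As far as these compounds go, what stays open is how far past that limit compound 2 and compound 3 lie, and whether any group on this carbonyl carbon gives stronger inhibition than 4-methylphenyl does. A (4-methylphenyl)amino group would separate the effect of the amino link from that of the ring's substitution, while an unsubstituted phenyl or a 4-methoxyphenyl group would show how much of the read-out in compound 1 depends on its methyl group.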